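Amine substituents on the shared core, compound 1 to compound 4

The source may hold more compounds than are shown below. What is called first, only, known or untested is meant among the compounds shown, and "the series" means these compounds.

Measured in a functional assay on MGC-803 cells (Homo sapiens) for inhibition, read by sulforhodamine B assay; a lower number here means a stronger inhibitor, a higher number a weaker inhibitor:
compound 1, `Cc1ccc(NC2=CC(=O)c3c(nc4n3[C@H]3OC[C@@H](O)[C@H]3OC4)C2=O)cc1`: 1550 nM
compound 2, `O=C1C=C(NC2CCCC2)C(=O)c2c1nc1n2[C@H]2OC[C@@H](O)[C@H]2OC1`: > 8000 nM, a limit of the assay and not a number
compound 3, `CCCN(CCC)C1=CC(=O)c2nc3n(c2C1=O)[C@H]1OC[C@@H](O)[C@H]1OC3`: > 16000 nM, again a limit and not a number

Compound 1 is therefore the only one of the three with a number; the other two values are limits. For the measured compounds named here, the single measured step, a step that the two limits leave unreadable from compound 2 to compound 3, runs between two limits and is unreadable in size, so it says nothing about the change now followed. Compound 4, `O=C1C(Nc2cccc(Cl)c2)=CC(=O)c2c1nc1n2[C@H]2OC[C@@H](O)[C@H]2OC1`, differs from compound 1 by 3-chlorophenyl in place of 4-methylphenyl on an amine nitrogen. Going by the values given here, no measured step touches a change on the aryl group of the amine; the two limits only show that the arylamino compound 1 is the one with a readable value. Compound 4 is expected to give 1500 nM, with a range from 500 nM to 5000 nM. The step of a 1.0-fold lower number from compound 1 to compound 4 (0.01 log units; within the scatter) is expected to stay within the usual scatter.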

Compound 4, half-maximal inhibitory concentration: 1530 nM
Estimate against measurement, compound 4: 1.0-fold (0.01 log units) below; low and high end bracket the measured number.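

In this assay, 3-chlorophenyl in place of 4-methylphenyl on an amine nitrogen gives a 1.0-fold lower number from compound 1 to compound 4 (0.01 log units; within the scatter). For the compounds shown here, this is the first readable comparison at this position, and the two aryl groups cannot be told apart in this read-out. No information shown here accounts for this result.

The pair alters the ring substituent and its ring location together, so neither can be judged alone. From the compounds shown here alone, whether the same holds for an aryl ring carrying a carboxylic acid or a dimethylamino group remains open.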